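Series notes: chloro in place of nitro, compound 2 to compound 3

The source may hold more compounds than are shown below. What is called first, only, known or untested is meant among the compounds shown, and "the series" means these compounds.

Two members of the series have been measured in a functional assay on PC-3 cells (Homo sapiens) for antiproliferative activity, read by MTT assay, tested at 1 uM; a lower number here means a weaker effect, a higher number a stronger effect of the compound at the concentration tested. Compound 1 `COc1cc(C(=O)N/N=C/c2c(Cl)cccc2Cl)cc(OC)c1OC` gives 43% there. Compound 2 `COc1cc(C(=O)N/N=C/c2ccc(Cl)c([N+](=O)[O-])c2)cc(OC)c1OC` gives 32.1% in this assay, the lowest of the two numbers; its nearest neighbour is compound 1, whose number lies higher by an amount beyond the usual scatter. Among the measured compounds shown here, no pair of measured compounds differs in a single place, so no measured step is available to lean on.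

Compound 3 `COc1cc(C(=O)N/N=C/c2ccc(Cl)c(Cl)c2)cc(OC)c1OC` has not yet been measured. It differs from compound 2 in one place: chloro in place of nitro on an aromatic carbon. With no measured step of this kind in the series, the change from compound 2 to compound 3 is expected to shift this assay only modestly, without a clear direction, and most likely not beyond the scatter. Compound 3 is therefore estimated at 38% in this assay, with a range from 20% to 56%. The step this estimate implies, a number 5.9 percentage points higher from compound 2 to compound 3 (within the scatter), is expected to stay within the scatter.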

Compound 3, a percentage reported as inhibition, at one concentration (the size of the read-out at that concentration, not a potency): 13.5%
Compound 3: the middle estimate sits 24.5 percentage points above what was measured; the measured number lies below the stated range.
By their numbers in this assay, from the lowest: compound 3; then compound 2; then compound 1.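

In this assay, among the compounds shown here, this aromatic carbon, ortho to a chloro group and meta to a large group, proves sensitive to what it carries: chloro in place of nitro gives a number 18.6 percentage points lower from compound 2 to compound 3 (beyond the scatter), a step beyond the scatter, whereas the earlier compounds offered no single-place comparison at all. The second step, with 3,4-dichlorophenyl in place of 2,6-dichlorophenyl, gives a number 29.5 percentage points lower from compound 1 to compound 3 (beyond the scatter), so the arrangement of the two chloro groups also counts, and compound 3 stands lowest of the three in both comparisons. No measurement at hand explains either step.

Open, going by these compounds, is whether the higher number of compound 2 is specific to nitro or would also be seen with another group on this carbon, such as an amine, a nitrile or a carboxylic acid. Also open, on these data alone, is whether the two steps in this assay would keep their direction and size at other concentrations, as a read-out at one concentration gives no potency.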